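Extending the alkyl chain on the shared core

The source may report more compounds than this note shows. Statements on the series, on what has been measured and on what is new or still open speak of the compounds shown alone.

Among the compounds with values here, compound 2 `CCCCCc1ccc(-c2cc3cn([C@H]4C[C@H](O)[C@@H](CO)O4)c(=O)nc3o2)cn1` gives 100000 nM in an ADME assay on HEL cells (Homo sapiens) for cytotoxicity, with a stated time of 3 days (a lower number here means that less compound is tolerated, a higher number that more compound is tolerated), the only plain number available among the measured compounds. Compound 1 `CCCc1ccc(CCc2cc3cn([C@H]4C[C@H](O)[C@@H](CO)O4)c(=O)nc3o2)cc1` gives in this assay a value that is a limit of the assay, >= 130000 nM. Compound 3 `CCCCCCc1ccc(-c2cc3cn([C@H]4C[C@H](O)[C@@H](CO)O4)c(=O)nc3o2)cn1` has not yet been measured in this assay. It differs from compound 2 by methyl in place of hydrogen on a saturated chain carbon, five bonds along the chain from an aromatic carbon. Within the data shown here, no step between measured compounds is known, so the expected step of a 1.3-fold lower number from compound 2 to compound 3 (0.10 log units; within the scatter) is small and not expected to pass beyond the scatter. For compound 3 the estimate in this assay is 80000 nM, expected between 30000 nM and 150000 nM.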

Compound 3, minimum cytotoxic concentration: 100000 nM
Compound 3: the middle estimate sits 1.3-fold (0.10 log units) below what was measured; the measured number falls inside the stated range.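

In this assay, putting methyl in place of hydrogen on a saturated chain carbon, five bonds along the chain from an aromatic carbon, gives no change at the digits printed from compound 2 to compound 3 (within the scatter). Within the data shown here, this is the first step that can be read at this position, and it shows that this chain tolerates one added carbon without a detectable change in this read-out. Compound 1 has a value that is a limit of the assay: the limit of >= 130000 nM in this assay, at which 1 of the 3 values shown sits.

As far as these compounds go, whether a longer chain at this position would keep the number in this assay stays open. So does the outcome of placing an amine or a carboxylic acid there.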